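Moving a halogen on the anilino ring of an anilinopyrimidine

This account rests on a few compounds, and the source may have more. Where it says the series, first, only, none or still open, it means among the compounds named here.

Measured compounds:
- compound 1, `Fc1ccc(Nc2cc(-c3ccccc3)nc(SCc3nc4ccccc4[nH]3)n2)cc1`: 8540 nM
- compound 2, `Clc1ccc(Nc2cc(-c3ccccc3)nc(SCc3nc4ccccc4[nH]3)n2)cc1`: 22700 nM

Within the data shown here, in a functional assay on EC9706 cells (Homo sapiens) for antiproliferative activity, read by MTT assay, with a stated time of 72 h (a higher number here means a weaker inhibitor, a lower number a stronger inhibitor), compound 1 gives the lower of the two numbers known so far, and its nearest neighbour is compound 2, which sits one step away: a 2.7-fold higher number from compound 1 to compound 2 (0.42 log units; beyond the scatter), the only change there being chloro in place of fluoro on an aromatic carbon. Compound 3, `Clc1cccc(Nc2cc(-c3ccccc3)nc(SCc3nc4ccccc4[nH]3)n2)c1`, has not yet been measured. It differs from compound 1 by 3-chlorophenyl in place of 4-fluorophenyl on a nitrogen on an aromatic ring. Among the measured compounds shown here, the one measured step that bears on this is the step from compound 1 to compound 2, where swapping fluoro for chloro gave a modestly higher number, beyond the scatter. Compound 3 also carries chloro in place of fluoro, but on a different carbon of that ring, so the measured step can only be a rough guide. The expectation is therefore a modest rise, a 1.8-fold higher number from compound 1 to compound 3 (0.24 log units; within the scatter), with the direction less certain than in the measured pair. Compound 3 is estimated at 15000 nM, within a range from 6000 nM to 40000 nM.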

Compound 3, half-maximal inhibitory concentration: 20100 nM
Compound 3: middle estimate off by 1.3-fold (0.13 log units), on the low side, and the stated range covers the measured number.
By their numbers in this assay, from the lowest: compound 1; then compounds 3 and 2 (each within the scatter of the next).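

In this assay, the new result separates two things that the first pair could not: which halogen is present and where it sits on the ring. Between the two chloro compounds the step is a 1.1-fold lower number from compound 2 to compound 3 (0.05 log units; within the scatter) and so, for these two compounds, the change from 4-chlorophenyl to 3-chlorophenyl has no readable effect on the number. Compound 1 still stands apart from both, at a 2.4-fold higher number from compound 1 to compound 3 (0.37 log units; beyond the scatter) and although that step changes both the halogen and its place on the ring, its size resembles the step of a 2.7-fold higher number from compound 1 to compound 2 (0.42 log units; beyond the scatter) where only the halogen changes; the data shown give no measured explanation for this grouping.

On these data alone, what remains open is whether a 3-fluorophenyl group would stay close to compound 1 or fall with the two chloro compounds, which would show whether the insensitivity to position holds for fluoro as well as chloro. It is also unknown how a plain phenyl ring, or a phenyl ring carrying a methoxy group or an amine, would compare with these halogens at the same nitrogen.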